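The source may hold more compounds than are shown below. What is called first, only, known or untested is meant among the compounds shown, and "the series" means these compounds.

Measured compounds:
compound 1 `O=C(CCCCCCNC(=O)C(O)(O)C(F)(F)F)Nc1ccncc1` — 6670 nM
compound 2 `O=C(CCCCNC(=O)c1cc(=O)c(O)co1)Nc1ccccc1` — a limit of the assay, > 100000 nM
compound 3 `O=C(CCCCCCCNC(=O)C(O)(O)C(F)(F)F)Nc1ccccc1` — 41700 nM

The assay is a functional assay on HCT-116 cells (Homo sapiens) for inhibition, read by colorimetric assay, with a stated time of 3 days; on this read-out higher numbers stand for weaker inhibition and lower numbers for stronger inhibition. Among the three compounds, compound 1 has the lowest number of the two that were read as numbers; compound 3 sits a clear distance above it, beyond the usual scatter. Compound 2 gave only a limit of the assay, (the limit of > 100000 nM in this assay, at which 1 of the 3 values shown sits), so no number exists for it. Going by the values given here, no two measured compounds differ in a single place, so no measured step is available.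

Compound 4 `O=C(CCCCCCNC(=O)C(O)(O)C(F)(F)F)Nc1nccs1` is not yet measured. It differs from compound 1 by 1,3-thiazol-2-yl in place of pyridin-4-yl on an amide-type nitrogen. Among the compounds with values here, with no measured step of this kind to lean on, the expectation for the step from compound 1 to compound 4 in this assay rests on compound 1 alone, whose value is 6670 nM; the step is expected to be small, a 1.5-fold higher number from compound 1 to compound 4 (0.18 log units; within the scatter), and may well lie within the scatter. Compound 4 is therefore estimated to give 10000 nM, between 3000 nM and 35000 nM.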

Compound 4, half-maximal inhibitory concentration: 10800 nM
Estimate against measurement, compound 4: 1.1-fold (0.03 log units) below; the range from low to high includes it.
By their numbers in this assay, from the lowest: compounds 1 and 4 (each within the scatter of the next); then compound 3. At a limit, above all of these: compound 2.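

In this assay, going by these compounds alone, the exchange of pyridin-4-yl for 1,3-thiazol-2-yl on the amide-type nitrogen gives the first step that can be read in a single place: a 1.6-fold higher number from compound 1 to compound 4 (0.21 log units; within the scatter). On this chain, then, a five-membered aromatic ring with 2 hetero atoms takes the place of a six-membered aromatic ring with 1 hetero atom with no change that stands clear of the scatter, so the pyridin-4-yl group is not needed to keep a reading of this size. Nothing measured here bears on the reason for this result.

On these data alone, how a 1,3-oxazol-2-yl or a pyridin-3-yl group would read on the same amide-type nitrogen stays open. So does whether the same exchange would give a step of this size on a longer chain.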